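Series notes: pyridin-4-yl in place of methylfuran

This account rests on a few compounds, and the source may have more. Where it says the series, first, only, none or still open, it means among the compounds named here.

Measured in a functional assay for inhibition, with Homo sapiens as the target (on this read-out lower numbers stand for stronger inhibition and higher numbers for weaker inhibition), for three compounds
compound 1 `CC1CCN(c2cccc(Nc3nccc(-c4cccs4)n3)c2)CC1` with 3500 nM as a number
compound 2 `Cc1cccc(Nc2nccc(-c3ccc(C)o3)n2)c1` with 2000 nM as a number
compound 3 `COc1ccc(N(C)c2nccc(-c3ccncc3)n2)cc1` with > 24000 nM as a limit of the assay

Compound 2 gives 2000 nM in this assay and compound 1 gives 3500 nM in the same read-out, so these two numbers lie within the usual scatter of each other. Only these two compounds have numbers.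

Compound 4 `Cc1cccc(Nc2nccc(-c3ccncc3)n2)c1` follows from compound 2 by a single change, pyridin-4-yl in place of 5-methylfuran-2-yl on an aromatic carbon with the rest kept.

Among the measured compounds shown here, no measured pair isolates this change. For the measured compounds named here, compound 3, the only measured compound with pyridin-4-yl, reads > 24000 nM as a limit and also differs from compound 4 elsewhere. A moderate rise in the number is therefore expected, though with wide uncertainty.

The expected change is a 3.0-fold higher number from compound 2 to compound 4 (0.48 log units; beyond the scatter) as an estimated weakening beyond the scatter.

Compound 4 is estimated at 6000 nM with an expected range of 1800 nM to 20000 nM for this measurement.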

Compound 4, half-maximal inhibitory concentration: 8800 nM
Compound 4: middle estimate off by 1.5-fold (0.17 log units), on the low side; low and high end bracket the measured number.
By their numbers in this assay, from the lowest: compounds 2 and 1 (each within the scatter of the next); then compound 4. At a limit, above all of these: compound 3.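

In this assay, among the compounds shown here, pyridin-4-yl in place of 5-methylfuran-2-yl on an aromatic carbon of the shared core gives a 4.4-fold higher number from compound 2 to compound 4 (0.64 log units; beyond the scatter), the first step that isolates this position. The two groups match in heavy atoms, hydrogen-bond donors and hydrogen-bond acceptors, yet the number changes beyond the scatter, so this position does not tolerate every aromatic ring equally, and compound 4 still gives a measurable number with pyridin-4-yl. Compound 3 reads only as a limit of the assay, not a number: the limit of > 24000 nM in this assay, at which 1 of the 4 values shown sits.

Still open, from the compounds shown here alone, is whether the step follows the ring size, the hetero atom or the methyl group, which a furan-2-yl without the methyl or a phenyl at this position would help separate. Going by these compounds, whether the step carries over to the other substituents of compound 1 also remains open.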